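The source may report more compounds than this note shows. Statements on the series, on what has been measured and on what is new or still open speak of the compounds shown alone.

Working notes on the series. Among the compounds with values here, in a functional assay on L1210 cells (Mus musculus), with a stated time of 1 days (a lower number here means a less potent compound, a higher number a more potent compound, by a factor of ten per unit of this negative logarithm), compound 2 `CCC(COC(N)=O)C1=C(N2CC2)C(=O)C(C)=C(N2CC2)C1=O` gives 6.03, the higher of the two numbers so far. Within the data shown here, its only neighbour is compound 1 `CC1=C(N2CC2)C(=O)C(C(C)COC(N)=O)=C(N2CC2)C1=O`, which in this assay gives 5.93; the step of a number 0.10 log units higher from compound 1 to compound 2 (within the scatter) is within the scatter, so no ranking of the two is claimed.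

Compound 3 `COCCOC(COC(N)=O)C1=C(N2CC2)C(=O)C(C)=C(N2CC2)C1=O` is not yet measured. It differs from compound 2 in one place: 2-methoxyethoxy in place of ethyl on a saturated chain carbon bound to a double-bonded ring carbon and a saturated chain carbon. Among the measured compounds shown here, the single measured step, a number 0.10 log units higher from compound 1 to compound 2 (within the scatter), is the only one that bears on this change, and only loosely: it adds a methyl on the same chain, whereas here 2-methoxyethoxy replaces ethyl on a saturated chain carbon bound to a double-bonded ring carbon and a saturated chain carbon. That one step stayed within the scatter, and nothing measured tests an oxygen-bearing chain of this kind, so no step beyond the scatter is expected in either direction, though with a wide range. Compound 3 is estimated at 5.9 in this assay, between 5.3 and 6.5. The expected step is a number 0.13 log units lower from compound 2 to compound 3 (within the scatter).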

Compound 3, logarithm of the reciprocal of the active concentration, log(1/C): 5.45
For compound 3 the middle estimate is 0.45 log units above the measured one; the range from low to high includes it.
By their numbers in this assay, from the lowest: compound 3; then compounds 1 and 2 (each within the scatter of the next).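

In this assay, the saturated chain carbon bound to a double-bonded ring carbon and a saturated chain carbon now shows a change beyond the scatter: with 2-methoxyethoxy in place of ethyl, the result is a number 0.58 log units lower from compound 2 to compound 3 (beyond the scatter), and with 2-methoxyethoxy in place of methyl, it is a number 0.48 log units lower from compound 1 to compound 3 (beyond the scatter). Both steps are modest and point the same way, whereas the earlier pair of compounds, with only methyl and ethyl at this place, gave a number 0.10 log units higher from compound 1 to compound 2 (within the scatter) and could not be ranked, so the position is not indifferent to every group placed on it. Nothing available explains the lower number of compound 3.

The compounds shown do not separate the two oxygens of 2-methoxyethoxy from its length, which a plain longer chain such as pentyl, or a shorter oxygen-bearing group such as methoxy, would begin to address. They also leave open how this place responds to a group of another kind, such as an amine or a carboxylic acid, and whether any group here can raise the number above those of compound 1 and compound 2.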